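The source may report more compounds than this note shows. Statements on the series, on what has been measured and on what is new or still open speak of the compounds shown alone.

In a functional assay on A549 cells (Homo sapiens) for inhibition, read by MTT assay, with a stated time of 72 h (a higher number here means a weaker inhibitor, a lower number a stronger inhibitor), three compounds have been measured:
compound 1 `CN(C(=O)NC(=O)c1cccc(C(F)(F)F)c1)c1nc(C(F)(F)F)c(C(=O)N/N=C/c2cccc(C(F)(F)F)c2)s1` gives 8.16 ug/mL;
compound 2 `CN(C(=O)NC(=O)c1ccc([N+](=O)[O-])cc1)c1nc(C(F)(F)F)c(C(=O)N/N=C/c2cccc(C(F)(F)F)c2)s1` gives 5.42 ug/mL;
compound 3 `Cc1nc(N(C)C(=O)NC(=O)c2c(F)cccc2F)sc1C(=O)N/N=C/c1ccccc1C(F)(F)F` gives 5.43 ug/mL.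

Compound 1 has the highest number of the three, yet its gaps to compound 3 and to compound 2 both lie within the scatter, so no ranking among them can be drawn. Compound 4 `CN(C(=O)NC(=O)c1cccc(C(F)(F)F)c1)c1nc(C(F)(F)F)c(C(=O)N/N=C/c2ccccc2C(F)(F)F)s1` has not been measured. It differs from compound 1 in one place: 2-(trifluoromethyl)phenyl in place of 3-(trifluoromethyl)phenyl on a carbon with a double bond to nitrogen. For the measured compounds named here, the one measured step, a 1.5-fold lower number from compound 1 to compound 2 (0.18 log units; within the scatter), concerns another part of the molecule and is within the scatter. Compound 3 also carries a 2-(trifluoromethyl)phenyl group on the carbon with a double bond to nitrogen, but it differs from compound 1 elsewhere too, and its value sits within the scatter of compound 1. No shift beyond the scatter is therefore expected, and the step of a 1.2-fold lower number from compound 1 to compound 4 (0.07 log units; within the scatter) is expected to be small. Compound 4 is estimated at 7 ug/mL, within a range from 3.5 ug/mL to 14 ug/mL.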

Compound 4, half-maximal inhibitory concentration: 12.1 ug/mL
For compound 4 the middle estimate is 1.7-fold (0.24 log units) below the measured one; the range from low to high includes it.
By their numbers in this assay, from the lowest: compounds 2, 3, 1 and 4 (each within the scatter of the next, the first and the last beyond it).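

In this assay, placing 2-(trifluoromethyl)phenyl instead of 3-(trifluoromethyl)phenyl on the carbon with a double bond to nitrogen gives a 1.5-fold higher number from compound 1 to compound 4 (0.17 log units; within the scatter) as the first step read at this place. The same atoms, joined differently, thus give two values that cannot be told apart, so this change alone sets no ranking between the two compounds. Nothing shown bears on why this is so. Still open, from the compounds shown here alone, is whether a different group at this place, such as an unsubstituted phenyl, a carboxylic acid on the ring or an amine on the ring, would give a step beyond the scatter.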